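This account rests on a few compounds, and the source may have more. Where it says the series, first, only, none or still open, it means among the compounds named here.

Among the compounds with values here, in a functional assay on K562 cells (Homo sapiens) for antiproliferative activity, read by MTT assay, with a stated time of 48 h (a lower number here means a stronger inhibitor, a higher number a weaker inhibitor), compound 3 `CN(C)CCCn1c(N)c(-c2nc3cc(Cl)ccc3[nH]2)c2nc(C#N)c(C#N)nc21` gives 10700 nM, the highest of the three numbers so far and beyond the scatter from both others. Compound 4 `CCN(CC)CCCCn1c(N)c(-c2nc3cc(Cl)ccc3[nH]2)c2nc(C#N)c(C#N)nc21` differs from it only in its side chain: (diethylamino)methyl in place of dimethylamino on a saturated chain carbon, three bonds along the chain from an aromatic nitrogen. Cut one bond further out, this reads as 3-(dimethylamino)propyl giving way to 4-(diethylamino)butyl.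

Within the data shown here, no measured step isolates this change. Among the measured compounds shown here, the only step available, a 2.0-fold lower number from compound 1 to compound 2 (0.29 log units; within the scatter), concerns a different place on the core and says nothing directly about the chain. The indirect evidence comes from two compounds that already carry the 4-(diethylamino)butyl chain, though with other groups on the shared core. Compound 1 `CCN(CC)CCCCn1c(N)c(-c2nc3ccccc3o2)c2nc(C#N)c(C#N)nc21` gives 1980 nM, and compound 2 `CCN(CC)CCCCn1c(N)c(-c2nc3ccccc3n2C)c2nc(C#N)c(C#N)nc21` gives 1010 nM. A lower number is therefore expected for compound 4, but with caution, since the core groups differ. The expected step is a 4.3-fold lower number from compound 3 to compound 4 (0.63 log units; beyond the scatter). For compound 4, the estimated value is 2500 nM, with an expected range from 800 nM to 8000 nM.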

Compound 4, half-maximal inhibitory concentration: 1270 nM
Compound 4: middle estimate off by 2.0-fold (0.29 log units), on the high side; the measured number falls inside the stated range.
By their numbers in this assay, from the lowest: compounds 2, 4 and 1 (each within the scatter of the next); then compound 3.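

In this assay the chain change can now be read directly. With the 5-chloro-1H-benzimidazol-2-yl group held fixed, 4-(diethylamino)butyl in place of 3-(dimethylamino)propyl gives a clear step (an 8.4-fold lower number from compound 3 to compound 4 (0.93 log units; beyond the scatter)). With the 4-(diethylamino)butyl chain in place, the group on the aromatic carbon does not separate the compounds: 5-chloro-1H-benzimidazol-2-yl replaces 1-methyl-1H-benzimidazol-2-yl (a 1.3-fold higher number from compound 2 to compound 4 (0.10 log units; within the scatter)) and 1,3-benzoxazol-2-yl (a 1.6-fold lower number from compound 1 to compound 4 (0.19 log units; within the scatter)).

On these data alone, the chain step alters both the chain length and the groups on the amine, so these compounds cannot separate the two; a 3-(diethylamino)propyl or 4-(dimethylamino)butyl chain would, and a piperidine at the chain end remains open too. Nothing measured here gives a reason for the step.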